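Methyl for trifluoromethyl on the oxadiazole of compound 1

The source may report more compounds than this note shows. Statements on the series, on what has been measured and on what is new or still open speak of the compounds shown alone.

Measured so far:
compound 1 `CCN(CC)S(=O)(=O)c1ccc(S(=O)(=O)N2CCC[C@@H](C(=O)N3CCN(c4nc(C(F)(F)F)no4)CC3)C2)cc1`: 60 nM
compound 2 `CCOC(=O)[C@H]1CCN(S(=O)(=O)c2ccc(S(=O)(=O)N(CC)CC)cc2)C1`: > 10000 nM
compound 3 `CCN(CC)C(=O)c1ccc(S(=O)(=O)N2CCC[C@@H](C(=O)N3CCN(c4nc(C(C)C)no4)CC3)C2)cc1`: 70 nM

In a functional assay on MIA PaCa-2 cells (Homo sapiens) for inhibition, read by MTT assay, with a stated time of 3 days (on this read-out higher numbers stand for weaker inhibition and lower numbers for stronger inhibition), compound 1 gives 60 nM, the lowest of the two numbers recorded, though its nearest neighbour, compound 3, gives 70 nM, a difference within the usual scatter, so the two cannot be ordered. Compound 2, which carries an ethyl ester in place of the piperazinyl amide, reaches only the limit of > 10000 nM in this assay, and that value is a limit rather than a number (the limit of > 10000 nM in this assay, at which 1 of the 3 values shown sits). Compound 1 and compound 3 differ in two places at once, so their closeness says only that an isopropyl on the oxadiazole, together with an amide in place of the second sulfonamide, gives a similar number.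

The unmeasured compound 4 `CCN(CC)S(=O)(=O)c1ccc(S(=O)(=O)N2CCC[C@@H](C(=O)N3CCN(c4nc(C)no4)CC3)C2)cc1` differs from compound 1 by methyl in place of trifluoromethyl on an aromatic carbon. Among the measured compounds shown here, no measured pair isolates this change. Compound 4 is estimated at 110 nM, between 40 nM and 350 nM, which means an expected step of a 1.8-fold higher number from compound 1 to compound 4 (0.26 log units; within the scatter), a small loss at most, possibly none beyond the scatter.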

Compound 4, half-maximal inhibitory concentration: 200 nM
Beside the measured number, compound 4's estimate is 1.8-fold (0.26 log units) below it; measured number inside the range.
By their numbers in this assay, from the lowest: compounds 1 and 3 (each within the scatter of the next); then compound 4. At a limit, above all of these: compound 2.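

In this assay, among the compounds shown here, exchanging the 3-(trifluoromethyl)-1,2,4-oxadiazol-5-yl group for the 3-methyl-1,2,4-oxadiazol-5-yl group gives a 3.3-fold higher number from compound 1 to compound 4 (0.52 log units; beyond the scatter), the first comparison in which only this position changes. The substituent on this carbon, between two ring nitrogen atoms, therefore affects the number on its own, although the modest step shows that methyl keeps much of the inhibition seen with trifluoromethyl. Nothing measured here accounts for the step.

Compound 3 carries isopropyl at this position but also differs from compound 1 in a second place, so it does not show how isopropyl alone compares with trifluoromethyl or methyl. The compounds shown leave open where an ethyl, a cyclopropyl or an amine on this carbon would fall, and whether the same step would hold with the amide of compound 3 in place of the second sulfonamide.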